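The source may report more compounds than this note shows. Statements on the series, on what has been measured and on what is new or still open speak of the compounds shown alone.

Compound 2 `CCCCCCOC(=O)c1cccc(-c2ccc(OCC)cc2)c1` stands lower of the two compounds measured in an assay on COS-7 cells for inhibition of patatin-like phospholipase domain-containing protein 2 (Mus musculus), tested at 200 uM (a lower number here means less inhibition, a higher number more inhibition at the concentration tested (going by the name of the read-out)), where compound 2 gives 48%. Compound 1 `CCCCOC(=O)c1cccc(-c2ccc(OCC)cc2)c1` gives 61%. Among the compounds with values here, the single measured step, a number 13 percentage points lower from compound 1 to compound 2 (beyond the scatter), came with ethyl in place of hydrogen on a saturated chain carbon, four bonds along the chain from an oxygen next to a carbonyl group. Compound 3 `CCNC(=O)c1cccc(-c2ccc(OCC)cc2)c1` differs from compound 2 by ethylamino in place of hexyloxy on a carbonyl carbon. Within the data shown here, that step bears only on the shorter chain; the change from an oxygen to a nitrogen on the carbonyl carbon has no measured counterpart. Compound 3 is therefore expected to move by a number 7 percentage points higher from compound 2 to compound 3 (within the scatter), to an estimated 55%, within 30% to 78%.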

Compound 3, a percentage reported as inhibition, at one concentration (the size of the read-out at that concentration, not a potency): 62%
Compound 3: middle estimate off by 7 percentage points, on the low side, and the stated range covers the measured number.
By their numbers in this assay, from the lowest: compound 2; then compounds 1 and 3 (each within the scatter of the next).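

Ethylamino in place of hexyloxy on the carbonyl carbon gives a number 14 percentage points higher from compound 2 to compound 3 (beyond the scatter) in this assay. Ethylamino in place of butoxy gives a number 1 percentage points higher from compound 1 to compound 3 (within the scatter), so among these compounds the ester oxygen is not needed for this level of inhibition. Nothing available here explains these results.

The compounds shown leave open how a hexylamino group would compare with ethylamino, a comparison that would separate the effect of the nitrogen from that of chain length. Where a carboxylic acid on this carbon would fall also remains open.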